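Cytotoxicity notes: from compound 3 to compound 4

This account rests on a few compounds, and the source may have more. Where it says the series, first, only, none or still open, it means among the compounds named here.

Compound 1 `Cc1ccc(S(=O)(=O)N[C@@H](CC(=O)NC(C)(C)C)C(=O)NCCNC(=O)Nc2ccccc2)cc1`: in an ADME assay on Karpas-1106P cells (Homo sapiens) for cytotoxicity (on this read-out higher numbers stand for an effect only at larger amounts of compound and lower numbers for an effect already at smaller amounts), compound 1 gives only a limit, > 11100 nM.
Compound 2 `Cc1ccc(S(=O)(=O)N[C@@H](CC(=O)NC(C)(C)C)C(=O)NCCNC(=O)c2cccc(C(C)C)c2)cc1`: in this assay compound 2 gives only a limit, > 11100 nM.
Compound 3 `Cc1ccc(S(=O)(=O)N[C@@H](CC(=O)NC(C)(C)C)C(=O)NCCNC(=O)c2ccc(Cl)cc2)cc1`: in this assay compound 3 gives only a limit, > 11100 nM.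

Compound 3 therefore stands nowhere distinct on the numbers shown: every measured value of the series sits at the same limit (the limit of > 11100 nM in this assay, at which 3 of the 3 values shown sit), and compound 3 shares it. The steps between the measured compounds, a step that the two limits leave unreadable from compound 1 to compound 2, a step that the two limits leave unreadable from compound 1 to compound 3 and a step that the two limits leave unreadable from compound 2 to compound 3, are all unreadable, since a step between two limits has no size.

Compound 4 `Cc1ccc(S(=O)(=O)N[C@@H](CC(=O)NC(C)(C)C)C(=O)NCCNC(=O)c2ccccc2O)cc1` differs from compound 3 by 2-hydroxyphenyl in place of 4-chlorophenyl on a carbonyl carbon. Among the compounds with values here, no measured step on a 2-hydroxyphenyl group exists, so the only bearing evidence is that three different groups on the carbonyl carbon all left the value at the limit in this assay. No step beyond the scatter is expected, and a step that the limit leaves unreadable from compound 3 to compound 4 is the expected outcome, most likely again as a limit. Compound 4 is estimated at 15000 nM, within 5000 nM to 50000 nM.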

Compound 4, half-maximal effective concentration: > 11100 nM
Compound 4 gave a limit, no number (the forecaster's own chance of this, stated with the estimate: 85%); the middle value lies beyond the limit too.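

In this assay, within the data shown here, compound 4 gives only a limit, > 11100 nM, so no step from compound 1, compound 2 or compound 3 to compound 4 can be read. The compounds shown leave open at what concentration any of them acts on these cells, and whether the group on the carbonyl carbon matters at all: the limit of > 11100 nM in this assay, at which 4 of the 4 values shown sit.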